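The compounds below may be only part of what the source reports. "The series", "measured", "known", "first", "only" and "open" are said of these compounds alone.

Measured in a functional assay on A549 cells (Homo sapiens) for antiproliferative activity, read by MTT assay, with a stated time of 72 h; on this read-out higher numbers stand for weaker inhibition and lower numbers for stronger inhibition:
- compound 1 `O=C1COc2ccc(-c3cnc(Cl)c(NS(=O)(=O)c4ccc(F)cc4)c3)cc2N1C1CCCCC1`: 37900 nM
- compound 2 `COc1ccc(N2C(=O)COc3ccc(-c4ccc(O)cc4)cc32)cc1`: > 40000 nM (a limit of the assay)
- compound 3 `COc1cccc(N2C(=O)COc3ccc(-c4cccc(NS(=O)(=O)c5ccc(F)cc5)c4)cc32)c1`: > 40000 nM (a limit of the assay)

Compound 3 has no number, only the limit > 40000 nM. The set as a whole sits mostly there: the limit of > 40000 nM in this assay, at which 2 of the 3 values shown sit. Going by the values given here, compound 1 gives 37900 nM, the one true number so far.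

The next compound is compound 4 `O=C1COc2ccc(-c3cccc(NS(=O)(=O)c4ccc(F)cc4)c3)cc2N1c1ccc(Cl)cc1`, which differs from compound 3 as follows: 4-chlorophenyl in place of 3-methoxyphenyl on an amide-type nitrogen in a ring. In words, 4-chlorophenyl stands in place of 3-methoxyphenyl on an amide-type nitrogen in a ring. Among the compounds with values here, no measured pair in the set isolates this change, so there is no direct precedent for its size.

In this assay no step beyond the scatter is expected, and no direction is favoured. The starting point for that expectation is compound 3, whose value > 40000 nM is a limit. The expected change is a number no higher from compound 3 to compound 4 (the limit leaves the size open). For compound 4 the estimated value is 40000 nM, with an expected range from 15000 nM to 80000 nM.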

Compound 4, half-maximal inhibitory concentration: 31600 nM
The estimate for compound 4 lay 1.3-fold (0.10 log units) above the measured number, and the stated range covers the measured number.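

Going by these compounds alone, on the amide-type nitrogen in a ring, 4-chlorophenyl in place of 3-methoxyphenyl gives the first pair that can be read at this position: in this assay there is an at least 1.2-fold lower number from compound 3 to compound 4 (0.10 log units; that floor lies within the scatter). With this aryl group, compound 4 gives a true number, 31600 nM, so the position can carry a measurable value, though the activity remains weak. The step has only a floor, and its real size stays unknown, because compound 3 is held at a limit of the assay: the limit of > 40000 nM in this assay, at which 2 of the 4 values shown sit.

Within the data shown here, no pair separates the chlorine from the methoxy group, or either substituent from its place on the phenyl ring. Also open, as far as these compounds go, is how a longer chain ending in an amine or a carboxylic acid on that nitrogen would read in this assay.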